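One Methyl Added: Expected Change in Cell Toxicity

A few compounds are considered here, and "the series" means these few. Any claim that something is new, unique, unknown or untested is made for them only; others in the source may bear on it.

Measured so far:
compound 1 `COc1cc2c(c(OC)c1O)C(=O)[C@H](O)[C@@H](c1ccc(O)cc1)O2`: 19.1%
compound 2 `COc1ccc([C@@H]2Oc3cc(OC)c(O)c(OC)c3C(=O)[C@@H]2O)cc1OC`: 22%
compound 3 `COc1cc([C@@H]2Oc3cc(OC)c(O)c(OC)c3C(=O)[C@@H]2O)ccc1O`: 1.6%

In a functional assay on PC-12 cells (Rattus norvegicus) for cytotoxicity, read by MTT assay, with stated times of 2 h and 4 h, tested at 32 ug/mL (a higher number here means a stronger effect of the compound at the concentration tested, a lower number a weaker effect), compound 3 gives 1.6%, while compound 2 gives 22%. The step of a number 20.4 percentage points higher from compound 3 to compound 2 (beyond the scatter) goes with the change (methyl in place of hydrogen on an oxygen on an aromatic ring). Compound 1 and compound 2 lie within the scatter of each other, and the difference between the core of compound 1 and the core of compound 3 is not broken down here. Compound 4 `COc1cc2c(c(OC)c1OC)C(=O)[C@H](O)[C@@H](c1ccc(O)cc1)O2` has not been measured; it arises from compound 1 by methyl in place of hydrogen on an oxygen on an aromatic ring, the same change as before, which occurs twice among these compounds. Resting on the single measured example a number 20.4 percentage points higher from compound 3 to compound 2 (beyond the scatter), an upward step of smaller size is expected, a number 9.9 percentage points higher from compound 1 to compound 4 (within the scatter), with wide uncertainty. Compound 4 is therefore estimated at 29%, in a range from 8% to 50%.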

Compound 4, a percentage reported as activity, at one concentration (the size of the read-out at that concentration, not a potency): 17.1%
Estimate against measurement, compound 4: 11.9 percentage points above; measured number inside the range.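

On the core of compound 1, going from hydroxy to methoxy gives a number 2 percentage points lower from compound 1 to compound 4 (within the scatter), so in this assay these two compounds cannot be told apart. The step seen on one core therefore did not carry over at the same size to the other: the same change on two cores in this assay, a number 20.4 percentage points higher (beyond the scatter) from compound 3 to compound 2 and a number 2 percentage points lower (within the scatter) from compound 1 to compound 4, 22.4 percentage points apart, beyond the scatter of two such steps. This rests on just one pair per core, so it shows that the result of this change depends on the core in these compounds, but not why, nor what it would do on a third core.

The compounds shown leave open what a longer chain on that oxygen would do in place of methyl. They also leave open whether an amine in place of the hydroxy group would behave differently on either core.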